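A few compounds are considered here, and "the series" means these few. Any claim that something is new, unique, unknown or untested is made for them only; others in the source may bear on it.

In a functional assay on HCT-116 cells (Homo sapiens) for inhibition, read by CCK-8 assay, with a stated time of 48 h (a lower number here means a stronger inhibitor, a higher number a weaker inhibitor), compound 1 `COc1cc(-c2ccnc3cc(-c4ccc(C)cc4)nn23)cc(OC)c1OC` gives 48 nM, while compound 2 `COc1cc(-c2ccnc3cc(-c4ccc(N(C)C)cc4)nn23)cc(OC)c1OC` gives 2050 nM, the higher of the two numbers and so the weaker inhibitor. Among the compounds with values here, the one measured step, a 43-fold higher number from compound 1 to compound 2 (1.63 log units; beyond the scatter), puts dimethylamino in place of methyl on an aromatic carbon, and it is large and beyond the scatter. Compound 3 `COc1cc(-c2ccnc3cc(-c4ccc(C(C)=O)cc4)nn23)cc(OC)c1OC` keeps the shared core and replaces that same dimethylamino group with acetyl: acetyl in place of dimethylamino on an aromatic carbon. Within the data shown here, no measured compound yet carries acetyl, so the direction is only a cautious expectation. The step to compound 2, a 43-fold higher number from compound 1 to compound 2 (1.63 log units; beyond the scatter), shows that changing this group can move the number a long way, and removing dimethylamino may recover part of that loss. The expected change is a 5.1-fold lower number from compound 2 to compound 3 (0.71 log units; beyond the scatter), towards a stronger inhibitor. The estimate for compound 3 is 400 nM, with an expected range from 90 nM to 1800 nM.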

Compound 3, half-maximal inhibitory concentration: 4390 nM
Beside the measured number, compound 3's estimate is 11-fold (1.04 log units) below it; measured number above the stated range.
By their numbers in this assay, from the lowest: compound 1; then compound 2; then compound 3.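

Swapping dimethylamino for acetyl does not recover the lost activity: in this assay the change gives a 2.1-fold higher number from compound 2 to compound 3 (0.33 log units; beyond the scatter), a modest step towards a weaker inhibitor. Measured against methyl, acetyl gives a 91-fold higher number from compound 1 to compound 3 (1.96 log units; beyond the scatter), a large loss, which makes compound 3 the weakest of the three and shows that two quite different groups at this position both fall far short of methyl. Nothing shown here explains why compound 1 stands so far ahead of the other two.

Within the data shown here, with only three groups at this position, it remains open whether methyl is unusually favourable or whether other small groups would do as well. Ethyl, chloro or an unsubstituted amine on the same aromatic carbon would help to settle that.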